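This account rests on a few compounds, and the source may have more. Where it says the series, first, only, none or still open, it means among the compounds named here.

Going by the values given here, compound 3 `CCn1c(=O)n(C(=O)NCCN2CCN(C)CC2)c2ccccc21` is the reference point of the series: in a functional assay for antagonist activity at 5-hydroxytryptamine receptor 4 (Cavia porcellus) (on this read-out higher numbers stand for higher potency (the scale is a negative logarithm) and lower numbers for lower potency), compound 3 gives 6.79, the only number measured so far. Compound 1 `CC(C)n1c(=O)n(C(=O)NCCN2CCN(C)CC2)c2ccccc21` reaches only a limit in this assay, < 6. Compound 2 `CCCCn1c(=O)n(C(=O)NCCN2CCN(C)CC2)c2ccccc21` likewise sits at a limit, < 6. The step of a number at least 0.79 log units higher from compound 1 to compound 3 (beyond the scatter) and the step of a number at least 0.79 log units higher from compound 2 to compound 3 (beyond the scatter) both run toward the smaller group on the aromatic nitrogen; the step that the two limits leave unreadable from compound 1 to compound 2 is not readable, both ends resting on (the limit of < 6 in this assay, at which 2 of the 3 values shown sit). Compound 4 `CN1CCN(CCNC(=O)n2c(=O)[nH]c3ccccc32)CC1` carries the same direction one step further: hydrogen in place of ethyl on an aromatic nitrogen. Whether the gain continues cannot be read from two limits. The step to compound 4 is therefore expected to be small, a number 0.01 log units higher from compound 3 to compound 4 (within the scatter). Compound 4 is estimated at 6.8, within 6 to 7.6.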

Compound 4, negative logarithm of the antagonist equilibrium constant: < 6
Compound 4 gave a limit, no number; the forecaster's own chance of this, stated with the estimate: 20%; middle value at least 0.80 log units from the limit.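

In this assay, hydrogen in place of ethyl on the aromatic nitrogen does not extend the gain seen toward compound 3; the change gives a number at least 0.79 log units lower from compound 3 to compound 4 (beyond the scatter), and compound 4 rests at a limit, not a number. At this position, only ethyl now gives a number, while hydrogen, isopropyl and butyl all end at the limit. The steps from compound 1 and compound 2 to compound 4 cannot be read: the limit of < 6 in this assay, at which 3 of the 4 values shown sit.

Open, going by these compounds, is whether methyl or propyl on this nitrogen gives a number. Also open, on these data alone, is how compound 1, compound 2 and compound 4 rank beyond their shared limit.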